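The source may report more compounds than this note shows. Statements on the series, on what has been measured and on what is new or still open speak of the compounds shown alone.

The three measured compounds share one core and differ only in the two groups attached through oxygen to their carbonyls. Compound 1 `CC1=C(C(=O)OC(C)(C)C)C(c2csc(-c3ccc(Cl)cc3)n2)C(C(=O)OC(C)(C)C)=C(C)N1` carries tert-butyl on both sides and in an assay on isolated protein for antagonist activity at Voltage-dependent L-type calcium channel subunit alpha-1C (Cavia porcellus), with a stated time of 15 min (on this read-out higher numbers stand for weaker inhibition and lower numbers for stronger inhibition), compound 1 gives 21000 nM. Compound 2 `CC1=C(C(=O)OC2CCCCC2)C(c2csc(-c3ccc(Cl)cc3)n2)C(C(=O)OC2CCCCC2)=C(C)N1` carries cyclohexyl on both sides, and in this assay compound 2 gives 11000 nM. Compound 3 `CCOC(=O)C1=C(C)NC(C)=C(C(=O)OCC(C)C)C1c1csc(-c2ccc(Cl)cc2)n1` carries ethyl on one side and isobutyl on the other; in this assay compound 3 gives 15400 nM. Among these three numbers that of compound 2 is the lowest, yet the gaps to compound 3 and to compound 1 both lie within the usual scatter, so no order among them can be read from these data.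

Compound 4 `COC(=O)C1=C(C)NC(C)=C(C(=O)OC2CCCCC2)C1c1csc(-c2ccc(Cl)cc2)n1` has not yet been measured in this assay. It differs from compound 2 in one place: methyl in place of cyclohexyl on an oxygen next to a carbonyl group. Among the measured compounds shown here, no step between two measured compounds isolates this kind of change, so the expectation rests only on the spread of the three numbers above, which all sit close together despite quite different groups on that oxygen. Compound 4 is therefore expected to give 14000 nM in this assay, within a range of 6000 nM to 35000 nM. The step that this estimate means, a 1.3-fold higher number from compound 2 to compound 4 (0.10 log units; within the scatter), is expected to be none beyond the scatter.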

Compound 4, half-maximal inhibitory concentration: 71900 nM
Estimate against measurement, compound 4: 5.1-fold (0.71 log units) below; measured number outside the range, above it.
By their numbers in this assay, from the lowest: compounds 2, 3 and 1 (each within the scatter of the next); then compound 4.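

The three earlier compounds changed the groups on both sides together, and their numbers stayed within the scatter of one another, so they gave no view of either group alone. Compound 4 isolates one such group: methyl in place of cyclohexyl on an oxygen next to a carbonyl group gives a 6.5-fold higher number from compound 2 to compound 4 (0.82 log units; beyond the scatter) in this assay, which shows that the group at this place can move the number beyond the scatter. The change removes a six-membered non-aromatic ring of carbon only and leaves the counts of hydrogen-bond donors and acceptors as they were, but nothing measured here accounts for the step.

With a single step of this kind, the compounds shown do not tell whether the rise in the number follows the loss of the ring or simply the loss of carbons, a question that ethyl, isopropyl or a longer open chain on this oxygen, with cyclohexyl kept on the other side, could address. They also leave open whether the same change gives a similar step when the other side carries a group such as tert-butyl or isobutyl instead of cyclohexyl.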